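A few compounds are considered here, and "the series" means these few. Any claim that something is new, unique, unknown or untested is made for them only; others in the source may bear on it.

Within the data shown here, in a functional assay on MCF7 cells (Homo sapiens) for antiproliferative activity, read by MTT assay, with a stated time of 72 h (a lower number here means a stronger inhibitor, a higher number a weaker inhibitor), three compounds sharing one core have numbers so far: compound 1 (`CC1=CC[C@H]2[C@H](CC[C@]2(C)O)C(C)(C)[C@@H]1CC[C@H]1[C@]2(C)CC[C@H](OC(=O)NCc3ccccc3)C(C)(C)O[C@H]2CC[C@@]1(C)O`) gives 24500 nM, compound 2 (`CC1=CC[C@H]2[C@H](CC[C@]2(C)O)C(C)(C)[C@@H]1CC[C@H]1[C@]2(C)CC[C@H](OC(=O)c3ccc(F)cc3)C(C)(C)O[C@H]2CC[C@@]1(C)O`) gives 33500 nM and compound 3 (`CC1=CC[C@H]2[C@H](CC[C@]2(C)O)C(C)(C)[C@@H]1CC[C@H]1[C@]2(C)CC[C@H](OC(=O)c3ccc(Cl)c(Cl)c3)C(C)(C)O[C@H]2CC[C@@]1(C)O`) gives 11900 nM, the lowest of the three. Compound 4 (`CC1=CC[C@H]2[C@H](CC[C@]2(C)O)C(C)(C)[C@@H]1CC[C@H]1[C@]2(C)CC[C@H](OC(=O)c3ccccc3C(F)(F)F)C(C)(C)O[C@H]2CC[C@@]1(C)O`) has 2-(trifluoromethyl)phenyl in place of 3,4-dichlorophenyl on a carbonyl carbon. The measured steps at this same place are a 2.8-fold lower number from compound 2 to compound 3 (0.45 log units; beyond the scatter) and a 2.1-fold lower number from compound 1 to compound 3 (0.31 log units; beyond the scatter), both modest, while the remaining one is a 1.4-fold higher number from compound 1 to compound 2 (0.14 log units; within the scatter). Among the measured compounds shown here, no measured compound carries 2-(trifluoromethyl)phenyl, so these steps give only a rough guide. A modest rise is therefore expected in this assay, an estimated 2.1-fold higher number from compound 3 to compound 4 (0.32 log units; beyond the scatter). For compound 4 the estimate is 25000 nM, with an expected range of 10000 nM to 55000 nM.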

Compound 4, half-maximal inhibitory concentration: 19200 nM
Beside the measured number, compound 4's estimate is 1.3-fold (0.11 log units) above it, within the range that was stated.
By their numbers in this assay, from the lowest: compounds 3, 4, 1 and 2 (each within the scatter of the next, the first and the last beyond it).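

In this assay, the 2-(trifluoromethyl)phenyl group of compound 4 lies within the scatter of all three earlier groups on this carbonyl carbon: a 1.6-fold higher number from compound 3 to compound 4 (0.21 log units; within the scatter), a 1.7-fold lower number from compound 2 to compound 4 (0.24 log units; within the scatter) and a 1.3-fold lower number from compound 1 to compound 4 (0.11 log units; within the scatter). Compound 4 therefore cannot be separated from compound 2 or compound 3, even though those two differ from each other beyond the scatter. No evidence here gives a cause for this result. Still open is how a carboxylic acid or a plain alkyl chain on this carbonyl carbon would compare, since every group shown carries a phenyl ring.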